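This account rests on a few compounds, and the source may have more. Where it says the series, first, only, none or still open, it means among the compounds named here.

Compound 1 `COC(=O)/C=C/c1cccc(N(Cc2ccc(-c3cccc(OC)c3)cc2)C(=O)NC(C)C)c1` gives 1370 nM in an assay on isolated protein with Bile acid receptor (Homo sapiens) as the target; a lower number here means that less compound is needed, a higher number that more compound is needed for the effect.
Compound 2 `COC(=O)/C=C/c1cccc(N(Cc2ccc(/C=C/C(=O)OC(C)(C)C)cc2OC)C(=O)C2CCCCC2)c1` gives only a limit, > 1000 nM, in this assay.
Compound 3 `COC(=O)/C=C/c1cccc(N(Cc2ccc(/C=C/C(=O)OC(C)(C)C)cc2OC(=O)c2ccccc2)C(=O)C2CCCCC2)c1` likewise gives only a limit, > 1000 nM, in this assay.

Compound 3 therefore stands at the edge of what this assay can report: a limit, not a number. Two of the three values shown sit at that same limit (the limit of > 1000 nM in this assay, at which 2 of the 3 values shown sit), and only compound 1 has a measured number. Compound 3 cannot be placed above or below compound 2 on these values. Among the compounds with values here, the one measured step that touches compound 3, a step that the two limits leave unreadable from compound 2 to compound 3, runs between two limits and its size cannot be read.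

Compound 4 `COC(=O)/C=C/c1cccc(N(Cc2ccc(/C=C/C(=O)OC(C)(C)C)cc2O)C(=O)C2CCCCC2)c1` differs from compound 3 in one place: hydrogen in place of benzoyl on an oxygen on an aromatic ring. Within the data shown here, no measured step shows this same change, and the only neighbouring step, a step that the two limits leave unreadable from compound 2 to compound 3, gives no size, so the change has no precedent that can be read in this assay. The expected step is a step that the limit leaves unreadable from compound 3 to compound 4, that is, no movement beyond the scatter in either direction. Compound 4 is expected to give about 2000 nM in this assay, within a range from 700 nM to 6000 nM, and a fair chance remains that only a limit is reported again.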

Compound 4, half-maximal effective concentration: > 1000 nM
Compound 4 was reported as a limit; the forecaster's own chance of this, stated with the estimate: 60%; the middle value is on the limit's open side.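

In this assay compound 4 gives only a limit, > 1000 nM. The steps among compound 2, compound 3 and compound 4 therefore cannot be read, as each runs between two limits: the limit of > 1000 nM in this assay, at which 3 of the 4 values shown sit. It remains open whether hydrogen, methyl or benzoyl on that oxygen makes any difference, and what actual number each of these compounds would give.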